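Dropping the Trifluoromethyl: What Clearance to Expect

This account rests on a few compounds, and the source may have more. Where it says the series, first, only, none or still open, it means among the compounds named here.

Of the compounds shown here, three that share one core have been measured in an ADME assay (liver) for metabolic stability, with Liver microsome (Homo sapiens) as the target, read by LC-MS, using microsomes, tested at 1 uM; on this read-out lower numbers stand for slow clearance and higher numbers for fast clearance. Compound 2 `CNc1nc(NCCCN(C)C)c2sc(-c3ccc(C(F)(F)F)cc3)cc2n1` gives 14 uL/min, the smallest of the three numbers. Compound 1 `CNc1nc(NCCCN(C)C)c2sc(-c3ccc(S(C)(=O)=O)cc3)cc2n1` gives 15 uL/min, and the step of a 1.1-fold lower number from compound 1 to compound 2 (0.03 log units; within the scatter) lies within the scatter, so these two cannot be told apart. Compound 3 `CNc1nc(NCCCN(C)C)c2sc(-c3ccoc3)cc2n1` gives 33.3 uL/min, a number that sits beyond the scatter above compound 2.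

Compound 4 `CNc1nc(NCCCN(C)C)c2sc(-c3ccccc3)cc2n1` has not yet been measured. It differs from compound 2 in a single place: hydrogen in place of trifluoromethyl on an aromatic carbon. The trifluoromethyl leaves and a hydrogen enters on an aromatic carbon of a six-membered aromatic ring of carbon only, para to a large group.

Going by the values given here, only one measured step touches this position, a 1.1-fold lower number from compound 1 to compound 2 (0.03 log units; within the scatter), and it changed nothing beyond the scatter. Among the compounds with values here, no measured step removes a group from this ring altogether, so there is no direct guide. The expected step of a 1.6-fold higher number from compound 2 to compound 4 (0.20 log units; within the scatter) is therefore modest, leaning toward a higher number, with wide uncertainty. Compound 4 is estimated at 22 uL/min, with a range from 11 uL/min to 45 uL/min.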

Compound 4, intrinsic clearance in a liver preparation (reported as CLH), per the amount of preparation that the assay uses: 5 uL/min
Estimate against measurement, compound 4: 4.4-fold (0.64 log units) above; measured number outside the range, below it.
By their numbers in this assay, from the lowest: compound 4; then compounds 2 and 1 (each within the scatter of the next); then compound 3.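

In this assay, the unsubstituted ring gives the lowest number of the four compounds, so this position matters more than the earlier swap suggested. Trading methylsulfonyl for trifluoromethyl changed nothing beyond the scatter, yet replacing either group with hydrogen does: there is a 2.8-fold lower number from compound 2 to compound 4 (0.45 log units; beyond the scatter) and also a 3.0-fold lower number from compound 1 to compound 4 (0.48 log units; beyond the scatter) in the same direction. The ring itself counts as well, with a 6.7-fold lower number from compound 3 to compound 4 (0.82 log units; beyond the scatter) when phenyl stands in place of furan-3-yl.

From the compounds shown here alone, it remains open whether a group smaller than these two, such as a single fluorine, a methoxy or an amine, would keep the number as low as hydrogen does on this aromatic carbon. Nothing available here explains why the number falls.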